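A few compounds are considered here, and "the series" means these few. Any claim that something is new, unique, unknown or untested is made for them only; others in the source may bear on it.

Measured compounds: compound 1 `Fc1ccccc1NC(=S)Nc1cccc(C(F)(F)F)c1` with 47000 nM in an ADME assay on MT4 cells (Homo sapiens) for cytotoxicity; on this read-out lower numbers stand for higher toxicity in this test and higher numbers for lower toxicity in this test; compound 2 `CCCCc1ccc(NC(=S)Nc2cccc(C(F)(F)F)c2)c(C)c1` with 43000 nM; compound 3 `Fc1ccc(NC(=S)Nc2cccc(C(F)(F)F)c2)cc1Cl` with 8000 nM.

Compound 1 gives the highest number of the three in this assay. Compound 2 stands within the scatter of compound 1, so the two cannot be told apart. Compound 3 stands beyond the scatter, with the clearly lower number, although it differs from compound 1 in more than one place.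

Compound 4 `Fc1cccc(NC(=S)Nc2cccc(C(F)(F)F)c2)c1` has not yet been measured. It differs from compound 1 by 3-fluorophenyl in place of 2-fluorophenyl on an amide-type nitrogen. Going by the values given here, no measured pair shows this change alone. The step of a 1.2-fold lower number from compound 1 to compound 4 (0.07 log units; within the scatter) is expected to stay within the scatter, in no clear direction. Compound 4 is estimated at 40000 nM, with a range from 15000 nM to 100000 nM.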

Compound 4, half-maximal cytotoxic concentration: 20000 nM
Compound 4: the middle estimate sits 2.0-fold (0.30 log units) above what was measured; measured number inside the range.
By their numbers in this assay, from the lowest: compound 3; then compound 4; then compounds 2 and 1 (each within the scatter of the next).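

In this assay, going by these compounds alone, 3-fluorophenyl in place of 2-fluorophenyl on an amide-type nitrogen gives a 2.4-fold lower number from compound 1 to compound 4 (0.37 log units; beyond the scatter) and is the first change here seen alone. With the same atoms joined differently, the place of the fluorine on this ring therefore bears on the read-out, not only which atoms are present. Nothing measured here explains this step.

The compounds shown leave open how an unsubstituted phenyl or a methoxyphenyl would read on this nitrogen. They also leave open whether a nitrile in place of the trifluoromethyl would alter the number.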